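The source may hold more compounds than are shown below. What is called first, only, known or untested is meant among the compounds shown, and "the series" means these compounds.

Four sulfonamides built on one shared core are considered here. Compound 1 `N#Cc1ccc(S(=O)(=O)N2C/C(=C\c3cccnc3)C(=O)/C(=C/c3ccccc3F)C2)cc1` is the reference; in a functional assay on SMMC-7721 cells (Homo sapiens) for cytotoxicity, read by MTT assay, with a stated time of 24 h (on this read-out lower numbers stand for stronger inhibition and higher numbers for weaker inhibition), compound 1 gives 15400 nM. Compound 2 `CC(=O)Nc1ccc(S(=O)(=O)N2C/C(=C\c3cccnc3)C(=O)/C(=C/c3ccccc3F)C2)cc1` carries acetamido in place of cyano on an aromatic carbon; in this assay compound 2 gives 10900 nM, and the step of a 1.4-fold lower number from compound 1 to compound 2 (0.15 log units; within the scatter) is small. Compound 3 `N#Cc1ccc(S(=O)(=O)N2C/C(=C\c3cccnc3)C(=O)/C(=C/c3ccccc3C(F)(F)F)C2)cc1` differs from compound 1 in the other aromatic ring by trifluoromethyl in place of fluoro on an aromatic carbon; in this assay compound 3 gives 9650 nM, with the step of a 1.6-fold lower number from compound 1 to compound 3 (0.20 log units; within the scatter) again within the scatter. All three measured numbers therefore lie close together.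

Compound 4 `CC(=O)Nc1ccc(S(=O)(=O)N2C/C(=C\c3cccnc3)C(=O)/C(=C/c3ccccc3C(F)(F)F)C2)cc1` has not yet been tested. It differs from compound 3 by acetamido in place of cyano on an aromatic carbon, which is the same change that leads from compound 1 to compound 2, made on the core of compound 3 rather than that of compound 1. For compound 4 the step in this assay is expected to be a 1.4-fold lower number from compound 3 to compound 4 (0.15 log units; within the scatter), because the same change earlier gave a 1.4-fold lower number from compound 1 to compound 2 (0.15 log units; within the scatter). On that basis compound 4 is estimated at 6900 nM, expected to fall between 3500 nM and 14000 nM.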

Compound 4, half-maximal inhibitory concentration: 9830 nM
Compound 4: the middle estimate sits 1.4-fold (0.15 log units) below what was measured, and the stated range covers the measured number.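

In this assay, acetamido in place of cyano gives a 1.0-fold higher number from compound 3 to compound 4 (0.01 log units; within the scatter), and set beside the earlier case, this change shows no difference between the two cores: the same change on two cores in this assay, a 1.4-fold lower number (0.15 log units; within the scatter) from compound 1 to compound 2 and a 1.0-fold higher number (0.01 log units; within the scatter) from compound 3 to compound 4, 1.4-fold (0.16 log units) apart, within the scatter of two such steps. Trifluoromethyl in place of fluoro, read on the core bearing the 4-acetamidophenyl group, gives a 1.1-fold lower number from compound 2 to compound 4 (0.04 log units; within the scatter), and this change also behaves alike on both cores: the same change on two cores in this assay, a 1.6-fold lower number (0.20 log units; within the scatter) from compound 1 to compound 3 and a 1.1-fold lower number (0.04 log units; within the scatter) from compound 2 to compound 4, 1.4-fold (0.16 log units) apart, within the scatter of two such steps. This shows that neither change depends measurably on the other within these four compounds, but every step is small, so it does not show that either change moves the number at all, and agreement among such small steps says little about how a larger step would carry over.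

The compounds shown leave open whether an amine or a carboxylic acid in place of cyano and acetamido, or a longer chain on the amide, would give a step beyond the scatter. They also leave open whether chloro or methoxy in place of fluoro and trifluoromethyl would carry from one core to the other in the same way.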